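Urea Variants of a Methoxyquinoline-Like Core in HeLa Cells

The source may hold more compounds than are shown below. What is called first, only, known or untested is meant among the compounds shown, and "the series" means these compounds.

Measured compounds:
Compound 1, `COc1cc(NC(C)CCCNC(=O)NNC(=O)Nc2ccc(Br)cc2)c2ncccc2c1`, 101000 nM
Compound 2, `COc1cc(NC(C)CCCNC(=O)NNC(=O)Nc2ccc(Cl)cc2)c2ncccc2c1`, 120000 nM
Compound 3, `COc1cc(NC(C)CCCNC(=O)Nc2ccc(Br)cc2)c2ncccc2c1`, 20000 nM

In a functional assay on HeLa cells (Homo sapiens) for inhibition, read by MTT assay, with a stated time of 72 h (on this read-out lower numbers stand for stronger inhibition and higher numbers for weaker inhibition), compound 3 gives the lowest number of the three, a 5.1-fold lower number from compound 1 to compound 3 (0.70 log units; beyond the scatter) and a 6.0-fold lower number from compound 2 to compound 3 (0.78 log units; beyond the scatter). Compound 4, `COc1cc(NC(C)CCCNC(=O)Nc2cccc(C(F)(F)F)c2)c2ncccc2c1`, differs from compound 3 only on the group attached to the amide-type nitrogen: 3-(trifluoromethyl)phenyl in place of 4-bromophenyl on an amide-type nitrogen. For the measured compounds named here, the one measured step that changes only the substituent of that ring is a 1.2-fold higher number from compound 1 to compound 2 (0.07 log units; within the scatter), which stayed within the scatter. On that basis compound 4 is expected to stay close to compound 3 in this assay, with no change at the digits printed from compound 3 to compound 4 (within the scatter) as the estimated step, in no direction beyond the scatter. The estimate for compound 4 is 20000 nM, with a range from 7000 nM to 60000 nM.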

Compound 4, half-maximal inhibitory concentration: 14000 nM
Compound 4: middle estimate off by 1.4-fold (0.15 log units), on the high side, within the range that was stated.
By their numbers in this assay, from the lowest: compounds 4 and 3 (each within the scatter of the next); then compounds 1 and 2 (each within the scatter of the next).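

In this assay, the step of a 1.4-fold lower number from compound 3 to compound 4 (0.15 log units; within the scatter) shows that this amide-type nitrogen accepts 3-(trifluoromethyl)phenyl in place of 4-bromophenyl without a change beyond the scatter. The separation from the compounds carrying the longer carbamoylamino groups also holds for this new aryl group, with an 8.6-fold lower number from compound 2 to compound 4 (0.93 log units; beyond the scatter) and a 7.2-fold lower number from compound 1 to compound 4 (0.86 log units; beyond the scatter). Nothing available explains these steps. The compounds shown leave open how an amine or a carboxylic acid on this aromatic ring would read, and whether 3-(trifluoromethyl)phenyl on the longer carbamoylamino group would track compound 1 and compound 2.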